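This account rests on a few compounds, and the source may have more. Where it says the series, first, only, none or still open, it means among the compounds named here.

Working notes on the series, read in a functional assay on MDA-MB-231 cells (Homo sapiens) for antiproliferative activity, read by MTT assay, with a stated time of 24 h; a higher number here means a weaker inhibitor, a lower number a stronger inhibitor. Compound 1 `COc1ccc(-c2noc(-c3ccccc3)n2)cc1OC1CCCC1` gives > 1000000 nM, which is a limit of the assay and not a number. Compound 2 `COc1ccc(-c2noc(-c3ccncc3)n2)cc1OC1CCCC1` gives 240000 nM. Compound 3 `COc1ccc(-c2noc(-c3ccc(F)cc3)n2)cc1OC1CCCC1` gives 55500 nM, the lowest number among the three.

Compound 4 `COc1ccc(-c2noc(-c3cccnc3)n2)cc1OC1CCCC1` follows from compound 3 by pyridin-3-yl in place of 4-fluorophenyl on an aromatic carbon, with pyridin-3-yl in place of 4-fluorophenyl. The closest measured change is a 4.3-fold lower number from compound 2 to compound 3 (0.64 log units; beyond the scatter), a modest step. The other two steps, an at least 4.1-fold lower number from compound 1 to compound 2 (0.61 log units; beyond the scatter) and an at least 18-fold lower number from compound 1 to compound 3 (1.25 log units; beyond the scatter), show that the phenyl compound lies well above both. Compound 4 is therefore expected to behave like the other pyridine, compound 2 at 240000 nM, which means a modest rise. The expected step is a 4.1-fold higher number from compound 3 to compound 4 (0.62 log units; beyond the scatter). For compound 4 the estimated value is 230000 nM, with an expected range of 70000 nM to 700000 nM.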

Compound 4, half-maximal inhibitory concentration: > 1000000 nM
Compound 4 was reported as a limit; the forecaster's own chance of this, stated with the estimate: 15%; at least 4.3-fold (0.63 log units) between middle value and limit.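

Compound 4 gives > 1000000 nM, which is a limit of the assay and not a number. Pyridin-3-yl in place of pyridin-4-yl gives an at least 4.1-fold higher number from compound 2 to compound 4 (0.61 log units; beyond the scatter), so at this position the place of the ring nitrogen counts, which the earlier compounds did not show. Pyridin-3-yl in place of 4-fluorophenyl gives an at least 18-fold higher number from compound 3 to compound 4 (1.25 log units; beyond the scatter).

As far as these compounds go, the step between compound 1 and compound 4 cannot be read: the limit of > 1000000 nM in this assay, at which 2 of the 4 values shown sit. Whether chloro or an amine in place of the fluoro of compound 3 would keep a number as low stays open.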